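Chloro for fluoro on the second core: cytotoxicity notes

The compounds below may be only part of what the source reports. "The series", "measured", "known", "first", "only" and "open" are said of these compounds alone.

Two cores carry the same pair of para substituents. Compound 1 `Cc1cc(CNS(=O)(=O)c2ccc(F)cc2)c(C)o1` and compound 2 `Cc1cc(CNS(=O)(=O)c2ccc(Cl)cc2)c(C)o1` share the first core; compound 3 `Cc1cc(CNS(=O)(=O)c2ccc(F)cc2)c(C)s1` and compound 4 `Cc1cc(CNS(=O)(=O)c2ccc(Cl)cc2)c(C)s1` share the second. The difference between the two cores is not broken down here.

In an ADME assay on MDCK cells (Canis lupus familiaris) for cytotoxicity, read by MTT assay, with a stated time of 24 h (on this read-out higher numbers stand for lower toxicity in this test and lower numbers for higher toxicity in this test), compound 1 gives 138000 nM, and compound 2 gives 55700 nM. The change between them is chloro in place of fluoro on an aromatic carbon, and it made a step of a 2.5-fold lower number from compound 1 to compound 2 (0.39 log units; beyond the scatter). For compound 3 the entry in this assay reads "not determined" (no result reported), so the second core has no measured anchor yet.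

The change from compound 3 to compound 4 is chloro in place of fluoro on an aromatic carbon; the place is the same as in the first pair, so this is the same change. Going by the values given here, with only one prior instance, and with compound 3 unmeasured, the expectation for compound 4 in this assay rests on the step of a 2.5-fold lower number from compound 1 to compound 2 (0.39 log units; beyond the scatter) and on the assumption that the second core sits in the same range as compound 1 at 138000 nM. The step is expected to be of the same direction and similar modest size, though a single example gives no strong footing. Compound 4 is therefore estimated at 50000 nM in this assay, within a range of 15000 nM to 160000 nM.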

Compound 4, half-maximal cytotoxic concentration: 52900 nM
Compound 4: the middle estimate sits 1.1-fold (0.02 log units) below what was measured; low and high end bracket the measured number.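

In this assay, going by these compounds alone, compound 3 has no single number to set against compound 4, so no step between the two can be read. Going by these compounds, it stays open whether chloro in place of fluoro moves the number on this core as on the first core, where the step is a 2.5-fold lower number from compound 1 to compound 2 (0.39 log units; beyond the scatter). No supporting data bear on the value of compound 4.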